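Adding a second fluorine to the benzyl group of compound 3

A few compounds are considered here, and "the series" means these few. Any claim that something is new, unique, unknown or untested is made for them only; others in the source may bear on it.

Compound 3 `CN(Cc1nc(C2CCN(Cc3ccc(F)cc3)CC2)no1)c1ncc(C(=O)NO)cn1` gives 65% in an assay on isolated protein for inhibition of protein deacetylase HDAC6 (Homo sapiens), read by fluorescence, with a stated time of 1 h, tested at 100 nM; a higher number here means more inhibition at the concentration tested (going by the name of the read-out), a lower number less inhibition. Its number sits between those of compound 1 `O=C(/C=C/c1ccc(OCc2nc(C3CCN(Cc4ccc(F)cc4F)CC3)no2)cc1)NO`, which gives 74%, and compound 2 `O=C(/C=C/c1ccc(OCc2nc(C3CCN(Cc4ccc(Br)cc4)CC3)no2)cc1)NO`, which gives 58%; both gaps lie within the scatter. Compound 4 `CN(Cc1nc(C2CCN(Cc3ccc(F)cc3F)CC2)no1)c1ncc(C(=O)NO)cn1` differs from compound 3 by fluoro in place of hydrogen on an aromatic carbon. Within the data shown here, no measured pair shows exactly this change. The nearest is the step of a number 16 percentage points lower from compound 1 to compound 2 (beyond the scatter), but there the 2,4-difluorophenyl gave way to 4-bromophenyl, so it only hints that the difluoro pattern goes with a somewhat higher number. Compound 4 is therefore expected to shift by a number 5 percentage points higher from compound 3 to compound 4 (within the scatter), a rise of small size or none beyond the scatter, and to give an estimated 70%, within 55% to 85%.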

Compound 4, a percentage reported as inhibition, at one concentration (the size of the read-out at that concentration, not a potency): 66%
Beside the measured number, compound 4's estimate is 4 percentage points above it; low and high end bracket the measured number.
By their numbers in this assay, from the lowest: compounds 2, 3, 4 and 1 (each within the scatter of the next, the first and the last beyond it).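

Compared directly for the first time, the change from 4-fluorobenzyl to 2,4-difluorobenzyl gives a number 1 percentage points higher from compound 3 to compound 4 (within the scatter) in this assay on the same core. A fluoro on this aromatic carbon, ortho to a large group, therefore leaves the inhibition at the tested concentration indistinguishable from that with hydrogen. Nothing measured on these compounds offers an explanation for this.

On these data alone, whether a chloro or a methoxy group on the same carbon would also leave the number unchanged remains open. So does whether this fluoro would have the same outcome on the core of compound 1.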